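The source may report more compounds than this note shows. Statements on the series, on what has been measured and on what is new or still open speak of the compounds shown alone.

Compound 1 `CCCn1c(=O)n(CCC(C)=O)c(=O)c2[nH]cnc21`: 3500 nM
Compound 2 `CCCn1c(=O)n(C)c(=O)c2[nH]cnc21`: 1600 nM
Compound 3 `CCCn1cnc2c1c(=O)n(C)c(=O)n2CCC`: 5000 nM

In a functional assay (trachea) with Cavia porcellus as the target (a lower number here means that less compound is needed, a higher number that more compound is needed for the effect), compound 3 gives 5000 nM, within the usual scatter of compound 1. The one clear gap around it is a 3.1-fold higher number from compound 2 to compound 3 (0.49 log units; beyond the scatter), a step that puts propyl in place of hydrogen on an aromatic nitrogen.

Compound 4 `C=CCCn1cnc2c1c(=O)n(C)c(=O)n2CCC` alters that propyl, turning it into but-3-en-1-yl: vinyl in place of methyl on a saturated chain carbon, two bonds along the chain from an aromatic nitrogen.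

For the measured compounds named here, no measured step changes the end of a chain in this way. The nearest guides are that propyl step and a 2.2-fold lower number from compound 1 to compound 2 (0.34 log units; beyond the scatter), where hydrogen replaces 2-oxopropyl. Each exchanges a whole group and is only modest, so no shift beyond the scatter is expected in this assay.

The expected step is a 1.1-fold lower number from compound 3 to compound 4 (0.05 log units; within the scatter).

Compound 4 is expected at about 4500 nM, with an estimated range of 1800 nM to 11000 nM.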

Compound 4, half-maximal effective concentration: 16800 nM
Estimate against measurement, compound 4: 3.7-fold (0.57 log units) below, outside the stated range (above it).
By their numbers in this assay, from the lowest: compound 2; then compounds 1 and 3 (each within the scatter of the next); then compound 4.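

In this assay, the far end of this chain is not a silent spot: vinyl in place of methyl gives a 3.4-fold higher number from compound 3 to compound 4 (0.53 log units; beyond the scatter) and so adds to the earlier rise. Measured from the bare aromatic nitrogen, but-3-en-1-yl gives an 11-fold higher number from compound 2 to compound 4 (1.02 log units; beyond the scatter), the largest step in this set. Nothing available explains why the number climbs here. This change adds both chain length and a double bond, and the compounds shown cannot separate the two. On these data alone, a saturated butyl chain would tell them apart, and an amine at the chain end remains untested ground.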